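This account rests on a few compounds, and the source may have more. Where it says the series, first, only, none or still open, it means among the compounds named here.

Among the compounds with values here, in a physicochemical assay for solubility, at pH 7 (a lower number here means a less soluble compound, a higher number a more soluble compound), compound 3 `CN1CCC(C(=O)N2Cc3c(NC(=O)c4ccc5ccccc5c4)n[nH]c3C2(C)C)CC1` gives 219000 nM, the only actual number among the measured compounds. Compound 1 `CN1CCC(C(=O)N2Cc3c(NC(=O)C4CCC4)n[nH]c3C2(C)C)CC1` reads > 225000 nM, which is a limit of the assay. Compound 2 `CN1CCC(C(=O)N2Cc3c(NC(=O)NCc4ccccc4)n[nH]c3C2(C)C)CC1` reads > 225000 nM, which is also a limit. Compound 4 `CN1CCC(C(=O)N2Cc3c(NC(=O)c4ccsc4)n[nH]c3C2(C)C)CC1` carries thiophen-3-yl in place of naphthalen-2-yl on a carbonyl carbon. Two measured changes at this same place bear on it: an at least 1.0-fold lower number from compound 1 to compound 3 (0.01 log units; that floor lies within the scatter) and an at least 1.0-fold lower number from compound 2 to compound 3 (0.01 log units; that floor lies within the scatter). Each is only a floor, and each lies within the scatter, so no step beyond the scatter is expected in this assay. The expected step is a 1.0-fold higher number from compound 3 to compound 4 (0.01 log units; within the scatter). Compound 4 is estimated at 225000 nM, with an expected range from 130000 nM to 350000 nM.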

Compound 4, solubility: > 225000 nM
Compound 4: a limit, no number; the forecaster's own chance of this, stated with the estimate: 65%; the middle value sits exactly at the limit.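

In this assay, thiophen-3-yl in place of naphthalen-2-yl on this carbonyl carbon gives an at least 1.0-fold higher number from compound 3 to compound 4 (0.01 log units; that floor lies within the scatter), so the floor of this step shows no change beyond the scatter. The reading for compound 4 is a limit, not a number, and its steps to compound 1 and compound 2 cannot be read. An aromatic ring containing sulfur thus joins the groups at this place that leave the read-out at its ceiling: the limit of > 225000 nM in this assay, at which 3 of the 4 values shown sit.

As far as these compounds go, what a long alkyl chain or a biphenyl group at this place would do remains open. So do the actual numbers behind the limits for compound 1, compound 2 and compound 4.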